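This account rests on a few compounds, and the source may have more. Where it says the series, first, only, none or still open, it means among the compounds named here.

Measured so far:
compound 1 `COc1cccc(N2C(=O)COc3ccc(-c4cnc(Cl)c(NS(=O)(=O)c5ccc(F)cc5)c4)cc32)c1` — > 40000 nM in a functional assay on HeLa cells (Homo sapiens) for antiproliferative activity, read by MTT assay, with a stated time of 72 h; a higher number here means a weaker inhibitor, a lower number a stronger inhibitor
compound 2 `O=C1COc2ccc(-c3cnc(Cl)c(NS(=O)(=O)c4ccc(F)cc4)c3)cc2N1C1CCCCC1` — 14300 nM
compound 3 `COc1cccc(N2C(=O)COc3ccc(-c4cnc5ccccc5c4)cc32)c1` — 11400 nM in this assay.

The value of compound 1 is a limit of this assay, not a number. The change cyclohexyl in place of 3-methoxyphenyl on an amide-type nitrogen in a ring gives an at least 2.7-fold lower number from compound 1 to compound 2 (0.44 log units; beyond the scatter); because compound 1 sits at the limit of > 40000 nM in this assay, at which 1 of the 3 values shown sits, only a lower bound of that step is known. Compound 3 carries a different core, and the difference between the two cores is not broken down here. Compound 4 `O=C1COc2ccc(-c3cnc4ccccc4c3)cc2N1C1CCCCC1` carries the same change made before, (cyclohexyl in place of 3-methoxyphenyl on an amide-type nitrogen in a ring). The step expected here is a 2.3-fold lower number from compound 3 to compound 4 (0.36 log units; beyond the scatter), and it rests on an at least 2.7-fold lower number from compound 1 to compound 2 (0.44 log units; beyond the scatter), tempered by the fact that the earlier step is only a bound. Compound 4 is therefore expected to give about 5000 nM in this assay, most likely between 1500 nM and 20000 nM.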

Compound 4, half-maximal inhibitory concentration: 19700 nM
Beside the measured number, compound 4's estimate is 3.9-fold (0.60 log units) below it; measured number inside the range.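

In this assay, cyclohexyl in place of 3-methoxyphenyl on the amide-type nitrogen gives a 1.7-fold higher number from compound 3 to compound 4 (0.24 log units; within the scatter), so on this core the swap has no effect that can be told from the scatter. The same swap therefore does not carry over from the core of compound 1 to the core of compound 3 with the same result: the same change on two cores in this assay, an at least 2.7-fold lower number (0.44 log units; beyond the scatter) from compound 1 to compound 2 and a 1.7-fold higher number (0.24 log units; within the scatter) from compound 3 to compound 4, at least 4.8-fold (0.68 log units) apart, beyond the scatter of two such steps

This does not show why the two cores differ, and the size of the first step remains unknown, since compound 1 gives a limit rather than a number: the limit of > 40000 nM in this assay, at which 1 of the 4 values shown sits.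

The compounds shown leave open how a straight butyl chain or an aminoethyl chain on that amide-type nitrogen would behave on either core.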